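The compounds below may be only part of what the source reports. "The series", "measured", "known", "first", "only" and "open" are said of these compounds alone.

Measured so far in a functional assay on NPC-TW01 cells (Homo sapiens) for antiproliferative activity, read by MTT assay, with a stated time of 72 h; on this read-out lower numbers stand for stronger inhibition of growth and higher numbers for weaker inhibition of growth:
compound 1, `COc1ccc(NC(=O)COc2ccc3c(=O)cc(-c4ccccc4)oc3c2)cc1`, gives 5970 nM;
compound 2, `O=C(COc1ccc2c(=O)cc(-c3ccccc3)oc2c1)Nc1ccc(-c2ccccc2)cc1`, gives 1610 nM;
compound 3, `COc1ccc(NC(=O)COc2ccc3c(=O)c(-c4ccccc4)coc3c2)cc1`, gives 6700 nM.

Compound 1 and compound 3 have the same atoms joined differently; the difference between the two cores is not broken down here, and their two values lie within the scatter of each other. Between compound 1 and compound 2 the change is phenyl in place of methoxy on an aromatic carbon, and it made a 3.7-fold lower number from compound 1 to compound 2 (0.57 log units; beyond the scatter) in this assay. Compound 4, `O=C(COc1ccc2c(=O)c(-c3ccccc3)coc2c1)Nc1ccc(-c2ccccc2)cc1`, carries the same change relative to compound 3, (phenyl in place of methoxy on an aromatic carbon), at a place described in the same words. Because a 3.7-fold lower number from compound 1 to compound 2 (0.57 log units; beyond the scatter) was seen for the same change on the core of compound 1, a step of about a 3.5-fold lower number from compound 3 to compound 4 (0.55 log units; beyond the scatter) is expected from compound 3 to compound 4. Compound 4 is therefore estimated at 1900 nM, with a range from 800 nM to 4500 nM.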

Compound 4, concentration for 50% growth inhibition: 1750 nM
The estimate for compound 4 lay 1.1-fold (0.04 log units) above the measured number; the range from low to high includes it.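

Phenyl in place of methoxy on an aromatic carbon gave a 3.8-fold lower number from compound 3 to compound 4 (0.58 log units; beyond the scatter) in this assay. Set beside the earlier step, the change carried over from one core to the other with much the same size: the same change on two cores in this assay, a 3.7-fold lower number (0.57 log units; beyond the scatter) from compound 1 to compound 2 and a 3.8-fold lower number (0.58 log units; beyond the scatter) from compound 3 to compound 4, 1.0-fold (0.01 log units) apart, within the scatter of two such steps

This rests on two pairs and a single change, so it shows transfer between these two cores only; it does not show that a third core would behave alike, that other changes would carry over, or why the step arises. The compounds shown leave open whether another group at that place, such as an amine, a carboxylic acid or a longer chain, would give matching steps on both cores. They also leave open what an ester in place of the amide would do.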